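Pyridin-3-yl for pyridin-2-yl in a histamine H2 agonist series

This account rests on a few compounds, and the source may have more. Where it says the series, first, only, none or still open, it means among the compounds named here.

Compound 1 `N=C(NCCCc1c[nH]cn1)NCCC(c1ccc(F)cc1)c1ccccn1` is measured in a functional assay on cardiac atrium for agonist activity at histamine H2 receptor (Cavia porcellus) (a higher number here means a larger maximal response, a lower number a smaller maximal response), and gives 1. Compound 2 `N=C(NCCCc1c[nH]cn1)NCCC(c1ccc(Cl)c(Cl)c1)c1ccccn1` gives 1 and compound 3 `N=C(NCCCc1c[nH]cn1)NCCC(c1ccccn1)c1cccs1` gives 1, so compound 1 stands level with both: no change at the digits printed from compound 1 to compound 2 (within the scatter), no change at the digits printed from compound 1 to compound 3 (within the scatter) and no change at the digits printed from compound 2 to compound 3 (within the scatter). Compound 4 `N=C(NCCCc1c[nH]cn1)NCCC(c1ccc(F)cc1)c1cccnc1` is not yet measured. It differs from compound 1 in this way: pyridin-3-yl in place of pyridin-2-yl on a saturated chain carbon bound to an aromatic carbon and a saturated chain carbon. The three known steps all exchange the other aryl group on the same saturated chain carbon and leave the pyridyl ring untouched, so none bears directly on this move; each of them stayed within the scatter. He therefore expects no step beyond the scatter, an estimated no change at the digits printed from compound 1 to compound 4 (within the scatter), and estimates that compound 4 will give 1 in this assay, between 0.8 and 1.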

Compound 4, intrinsic activity: the largest response reached, as a fraction of the reference agonist's: 1
The estimate for compound 4 equals the measured number at the digits printed; measured number inside the range.
By their numbers in this assay, from the lowest: compounds 1, 2, 3 and 4 (each within the scatter of the next).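

In this assay, going by these compounds alone, the pyridyl ring itself now proves open to change at this saturated chain carbon: pyridin-3-yl in place of pyridin-2-yl gives no change at the digits printed from compound 1 to compound 4 (within the scatter), whereas the earlier steps exchanged only the other aryl group. This rests on a single exchange, made with 4-fluorophenyl as the other aryl group. Nothing available accounts for the result. The compounds shown leave open whether pyridin-4-yl or a plain phenyl in this place would keep the maximal response, and whether pyridin-3-yl would do so alongside 3,4-dichlorophenyl or thiophen-2-yl.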